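Extending the ethyl chain on the shared core of compound 1

The source may hold more compounds than are shown below. What is called first, only, known or untested is meant among the compounds shown, and "the series" means these compounds.

Compound 1 `CCc1cnc2c(C#N)c(N3CCN(c4ncccn4)CC3)ccn12` > 3160 nM
Compound 2 `N#Cc1c(-c2ccc(N3CCCCC3)cc2)ccn2c(CC(F)(F)F)cnc12` 234 nM
Compound 3 `CCCCn1ccc(N2CCN(c3nc(C)cc(C)n3)CC2)c(C#N)c1=O` 631 nM

In a functional assay on CHO cells with metabotropic glutamate receptor 2 (Homo sapiens) as the target, read by GTPgammaS binding (a higher number here means that more compound is needed for the effect, a lower number that less compound is needed), compound 1 gives no number, only a limit, > 3160 nM. Its position among the three is that of the limit of > 3160 nM in this assay, at which 1 of the 3 values shown sits. Compound 2 gives 234 nM in this assay, and compound 3 gives 631 nM; neither differs from compound 1 in a single place, so their values do not describe any one change. Compound 4 `N#Cc1c(N2CCN(c3ncccn3)CC2)ccn2c(CCC3CC3)cnc12` differs from compound 1 by cyclopropyl in place of hydrogen on a saturated chain carbon, two bonds along the chain from an aromatic carbon. Within the data shown here, no measured pair covers this change, so its effect is not known from the numbers; a modest move toward a lower number is expected, an at least 1.5-fold lower number from compound 1 to compound 4 (0.19 log units; that floor lies within the scatter). For compound 4 the estimate in this assay is 2000 nM, between 500 nM and 8000 nM.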

Compound 4, half-maximal effective concentration: 1100 nM
The estimate for compound 4 lay 1.8-fold (0.26 log units) above the measured number; the range from low to high includes it.
By their numbers in this assay, from the lowest: compound 2; then compounds 3 and 4 (each within the scatter of the next). At a limit, above all of these: compound 1.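

In this assay, cyclopropyl in place of hydrogen on a saturated chain carbon, two bonds along the chain from an aromatic carbon, gives an at least 2.8-fold lower number from compound 1 to compound 4 (0.45 log units; beyond the scatter). Among these compounds, this is the first change at this position that can be read in single-place terms, and it moves the number downward. The step is only a floor, not a full size, since the value of compound 1 is a limit: the limit of > 3160 nM in this assay, at which 1 of the 4 values shown sits.

Going by these compounds, whether the lower number belongs to the cyclopropyl ring itself or simply to a longer chain stays open, and a butyl chain on the same core would separate the two. On these data alone, how an amine at the end of this chain would read is also open.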